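Swapping Halogenated Anilines Across a Shared Core

This account rests on a few compounds, and the source may have more. Where it says the series, first, only, none or still open, it means among the compounds named here.

Compound 1 `O=C(CSc1nc(Nc2ccccc2)c2ccccc2n1)Nc1ccc(Cl)cc1Cl` and compound 2 `O=C(CSc1nc(Nc2ccccc2)c2ccccc2n1)Nc1ccc(F)c(Cl)c1` share one core and differ only in the aryl group on an amide-type nitrogen. In a functional assay on MDA-MB-231 cells (Homo sapiens) for inhibition, read by MTT assay, with a stated time of 72 h (on this read-out lower numbers stand for stronger inhibition and higher numbers for weaker inhibition), compound 1 gives 19400 nM and compound 2 gives 21600 nM; the change 2,4-dichlorophenyl in place of 3-chloro-4-fluorophenyl on an amide-type nitrogen produced a 1.1-fold lower number from compound 2 to compound 1 (0.05 log units; within the scatter). Compound 3 `C=CC(=O)Nc1cccc(NC(=O)CSc2nc(Nc3ccc(F)c(Cl)c3)c3ccccc3n2)c1` rests on a different core, and the difference between the two cores is not broken down here; in this assay compound 3 gives 10600 nM. Compound 4 `C=CC(=O)Nc1cccc(NC(=O)CSc2nc(Nc3ccc(Cl)cc3Cl)c3ccccc3n2)c1` has not been measured. It arises through (2,4-dichlorophenyl in place of 3-chloro-4-fluorophenyl on a nitrogen on an aromatic ring), the same kind of change as from compound 2 to compound 1, though the place now is a nitrogen on an aromatic ring whose other neighbours are aromatic carbon rather than an amide-type nitrogen whose other neighbours are carbonyl carbon. Because a 1.1-fold lower number from compound 2 to compound 1 (0.05 log units; within the scatter) stayed within the scatter, the step is expected to be a 1.1-fold lower number from compound 3 to compound 4 (0.05 log units; within the scatter). Compound 4 is therefore estimated at 9500 nM in this assay, between 4500 nM and 20000 nM.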

Compound 4, half-maximal inhibitory concentration: 23100 nM
The estimate for compound 4 lay 2.4-fold (0.39 log units) below the measured number; measured number above the stated range.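

In this assay, placing 2,4-dichlorophenyl in place of 3-chloro-4-fluorophenyl on a nitrogen on an aromatic ring gave a 2.2-fold higher number from compound 3 to compound 4 (0.34 log units; beyond the scatter). Set beside the earlier step, this result does not separate the two cores: the same change on two cores in this assay, a 1.1-fold lower number (0.05 log units; within the scatter) from compound 2 to compound 1 and a 2.2-fold higher number (0.34 log units; beyond the scatter) from compound 3 to compound 4, 2.4-fold (0.38 log units) apart, within the scatter of two such steps The two steps therefore show no firm effect of the core on this change, but they also do not show that it carries over unchanged, and the two pairs differ in where the change sits as well as in their cores.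

The compounds shown leave open how a methoxyphenyl or pyridyl group would read on that nitrogen. They also leave open whether a saturated propanamide in place of the acrylamide would alter the step.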